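Methyl on the benzyl ring combined with the longer chain

The compounds below may be only part of what the source reports. "The series", "measured", "known", "first", "only" and "open" are said of these compounds alone.

Measured so far:
compound 1 `Cc1ccc(Cn2ccnc2/C=N/Nc2nc(NCCN(C)C)c3ccccc3n2)cc1` — 2750 nM
compound 2 `CN(C)CCCNc1nc(N/N=C/c2nccn2Cc2ccccc2)nc2ccccc12` — 2130 nM

Of the compounds shown here, two on the shared core have been read in a functional assay on SGC-7901 cells (Homo sapiens) for cytotoxicity, read by MTT assay, with a stated time of 72 h; on this read-out lower numbers stand for stronger inhibition and higher numbers for weaker inhibition. Compound 1 `Cc1ccc(Cn2ccnc2/C=N/Nc2nc(NCCN(C)C)c3ccccc3n2)cc1` gives 2750 nM, and compound 2 `CN(C)CCCNc1nc(N/N=C/c2nccn2Cc2ccccc2)nc2ccccc12` gives 2130 nM. The two values lie within the usual scatter of each other, so compound 2 is not separated from compound 1 on these numbers. Going by the values given here, compound 1 and compound 2 differ in two places at once, the methyl on the benzyl ring and the length of the amine chain, so no single-point step can be drawn between them.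

Compound 3 `Cc1ccc(Cn2ccnc2/C=N/Nc2nc(NCCCN(C)C)c3ccccc3n2)cc1` keeps the chain of compound 2 and takes on the change methyl in place of hydrogen on an aromatic carbon, para to a large group; one bond further out, benzyl to 4-methylbenzyl. Among the compounds with values here, no measured pair isolates this change. The same methyl is present in compound 1, and the comparison of compound 1 with compound 2, confounded as it is by the chain, shows no separation beyond the scatter. In this assay the expected step is a 1.1-fold higher number from compound 2 to compound 3 (0.03 log units; within the scatter), nothing beyond the scatter in either direction. Compound 3 is expected at 2300 nM, within a range from 1000 nM to 5300 nM.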

Compound 3, half-maximal inhibitory concentration: 2600 nM
The estimate for compound 3 lay 1.1-fold (0.05 log units) below the measured number; measured number inside the range.
By their numbers in this assay, from the lowest: compounds 2, 3 and 1 (each within the scatter of the next).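

In this assay the step from benzyl to 4-methylbenzyl can now be read in one place: a 1.2-fold higher number from compound 2 to compound 3 (0.09 log units; within the scatter) with the longer chain held fixed, so methyl in place of hydrogen on an aromatic carbon, para to a large group, is not separated from hydrogen here. The chain can now be read alone as well, with the 4-methylbenzyl group held fixed: a 1.1-fold lower number from compound 1 to compound 3 (0.02 log units; within the scatter) for (dimethylamino)methyl in place of dimethylamino, so the two changes that stood confounded between compound 1 and compound 2 each remain within the scatter when taken singly. No measurement at hand bears on what lies behind either step.

Open, going by these compounds, is whether a group other than methyl on the same aromatic carbon, such as chlorine, a methoxy group or a carboxylic acid, would give a step beyond the scatter. Open too, on these data alone, is whether a morpholine or a piperidine in place of dimethylamino, or a still longer chain, would separate from compound 2 and compound 3 in this assay.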